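Changing One Amide Side Group in a Cell-Killing Series

A few compounds are considered here, and "the series" means these few. Any claim that something is new, unique, unknown or untested is made for them only; others in the source may bear on it.

Compound 1 `C=C(CC)C(=O)c1ccc(OCC(=O)NCCCN2CCCC2=O)c(Cl)c1Cl` carries a 3-(2-oxopyrrolidin-1-yl)propyl group on an amide-type nitrogen. For the measured compounds named here, in a functional assay on CLL cells (Homo sapiens) for cytotoxicity, read by MTT assay, with a stated time of 48 h (a higher number here means that more compound is needed for the effect, a lower number that less compound is needed), compound 1 gives 13800 nM as its result, the only exact number available so far. Compound 2 `C=C(CC)C(=O)c1ccc(OCC(=O)Nc2ccc(S(=O)(=O)O)cc2)c(Cl)c1Cl` has only a limit to show, > 25000 nM, and not an exact number.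

Compound 3 `C=C(CC)C(=O)c1ccc(OCC(=O)Nc2ccc3nc[nH]c3c2)c(Cl)c1Cl` keeps the shared core of compound 1 and alters that one group. The exchange puts 1H-benzimidazol-6-yl in place of 3-(2-oxopyrrolidin-1-yl)propyl on an amide-type nitrogen, and it counts out as follows: 1H-benzimidazol-6-yl in place of 3-(2-oxopyrrolidin-1-yl)propyl on an amide-type nitrogen is the whole difference between the two structures.

Going by the values given here, no measured pair of compounds differs in just one place, so the data offer no direct guide to the size of this step. Resting on compound 1 at 13800 nM as the sole anchor, the expected 1.4-fold lower number from compound 1 to compound 3 (0.14 log units; within the scatter) is none beyond the usual scatter, with a slight lean toward less compound being needed. For compound 3 the estimated value in this assay is 10000 nM, with an expected range from 3500 nM to 25000 nM overall.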

Compound 3, half-maximal effective concentration: 3200 nM
Compound 3: middle estimate off by 3.1-fold (0.49 log units), on the high side; the measured number lies below the stated range.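

In this assay, for the compounds shown here, the exchange on the amide-type nitrogen gives a 4.3-fold lower number from compound 1 to compound 3 (0.63 log units; beyond the scatter), the first step in this set that can be read, so this position can clearly shift the amount of compound needed. The two groups have the same heavy-atom count, which means that count alone does not separate them; the 1H-benzimidazol-6-yl group differs in having two aromatic rings, a second nitrogen in place of the oxygen, and a hydrogen-bond donor, and one step cannot say which of these features matters. Compound 2 has only a limit rather than an exact number, so no step involving it can be read: the limit of > 25000 nM in this assay, at which 1 of the 3 values shown sits.

On these data alone, it remains open whether a plain phenyl group, with no ring nitrogen, would give a number like that of compound 3, or whether the ring nitrogens and their hydrogen are needed. An open-chain amine on a propyl chain would likewise help to show whether the lactam ring of compound 1 or the chain itself goes with its higher number.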